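Compound 4: benzyl in place of aryl on the core

A few compounds are considered here, and "the series" means these few. Any claim that something is new, unique, unknown or untested is made for them only; others in the source may bear on it.

Compound 1 `CCOc1ccc(-c2nn3cc(-c4cccc(N)c4)nc3s2)cc1`: in a functional assay on CCRF-CEM cells (Homo sapiens) for inhibition, read by cell counting, with a stated time of 3 days (on this read-out higher numbers stand for weaker inhibition and lower numbers for stronger inhibition), compound 1 gives > 250000 nM, which is a limit of the assay and not a number.
Compound 2 `C=C(Br)C(=O)Nc1cccc(-c2cn3nc(-c4ccc(OCC)cc4)sc3n2)c1`: compound 2 gives 1400 nM.
Compound 3 `COc1ccc(-c2nn3cc(-c4cccc(N)c4)nc3s2)cc1OC`: compound 3 gives 14000 nM.

Compound 2 stands lowest of the two numbers shown; compound 3 is the nearest, a step beyond the scatter above it, and the remaining value is the limit noted for compound 1.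

One step is measured: an at least 170-fold lower number from compound 1 to compound 2 (2.25 log units; beyond the scatter). It concerns the nitrogen on the aromatic ring, not the group on the five-membered ring of the core, so it does not speak to the change now considered. Compound 1 sits at the limit of > 250000 nM in this assay, at which 1 of the 3 values shown sits. Compound 3 carries a different substitution on the same aryl and gives a number, which shows only that the aryl end is not indifferent.

Compound 4 `C=C(Br)C(=O)Nc1cccc(-c2cn3nc(Cc4ccc(OC)cc4)sc3n2)c1` differs from compound 2 in one place: 4-methoxybenzyl in place of 4-ethoxyphenyl on an aromatic carbon. Among the compounds with values here, no measured step covers this change. A higher number is expected, of moderate size, since the aryl attached directly to the core is exchanged for a benzyl. The estimate for compound 4 is 6000 nM, within 1500 nM to 40000 nM, which means an expected step of a 4.3-fold higher number from compound 2 to compound 4 (0.63 log units; beyond the scatter).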

Compound 4, half-maximal inhibitory concentration: 2300 nM
Compound 4: middle estimate off by 2.6-fold (0.42 log units), on the high side; low and high end bracket the measured number.
By their numbers in this assay, from the lowest: compounds 2 and 4 (each within the scatter of the next); then compound 3. At a limit, above all of these: compound 1.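

In this assay, 4-methoxybenzyl in place of 4-ethoxyphenyl on this aromatic carbon gives a 1.6-fold higher number from compound 2 to compound 4 (0.22 log units; within the scatter), so this read-out does not separate the pair. With the (1-bromoethenyl)carbonyl group kept on the nitrogen, the aryl attached directly to the core is therefore not required at this position, at least for this one exchange, in which the leaving and entering groups have the same atoms joined differently. Nothing measured here accounts for this result.

The change alters both the link to the core and the alkoxy group, and the compounds shown do not separate these two parts. Also open, from the compounds shown here alone, is whether a longer chain such as 2-phenylethyl, or a benzyl carrying an amine or a carboxylic acid, would keep the number at this carbon.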